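The source may report more compounds than this note shows. Statements on the series, on what has been measured and on what is new or still open speak of the compounds shown alone.

Working notes on the pyrazoline amide series.

Three compounds carry numbers in a functional assay on MGC-803 cells (Homo sapiens) for cytotoxicity, read by MTT assay, with a stated time of 48 h; a higher number here means a weaker inhibitor, a lower number a stronger inhibitor. Compound 1 `CCN(CC)CC(=O)N1N=C(C)CC1c1ccccc1O` gives 39800 nM. Compound 2 `COc1ccccc1C1CC(C)=NN1C(=O)CN1CCC(OC)CC1` gives 9550 nM. Compound 3 `CNCC(=O)N1N=C(c2cc3ccccc3oc2=O)CC1c1ccccc1` gives 12800 nM. On these numbers compound 3 stands second highest of the three; its nearest neighbour is compound 2, and the gap between them lies within the scatter, so no order between compound 2 and compound 3 can be read. The gap from compound 3 to compound 1 lies beyond the scatter, with compound 1 the higher number of the two. For the measured compounds named here, no pair among the measured compounds differs in only one place, so no single step has been quantified.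

The next compound to be measured is compound 4 `O=C(CN1CCC(O)CC1)N1N=C(c2cc3ccccc3oc2=O)CC1c1ccccc1`. It is derived from compound 3 by one change:

4-hydroxypiperidin-1-yl in place of methylamino on a saturated chain carbon bound to a carbonyl carbon

The two compounds that carry a cyclic amine on that carbon, compound 1 and compound 2, sit on different cores and differ from each other beyond the scatter, so they give no usable reference for this change. The step from compound 3 to compound 4 in this assay is expected to stay within the scatter, as a 1.3-fold lower number from compound 3 to compound 4 (0.11 log units; within the scatter). Compound 4 is therefore expected at 10000 nM, with a range from 3000 nM to 32000 nM.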

Compound 4, half-maximal inhibitory concentration: "not active" (no number reported)
Compound 4 has no reported number here; there is nothing to compare the estimate with.
By their numbers in this assay, from the lowest: compounds 2 and 3 (each within the scatter of the next); then compound 1.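

In this assay, for the compounds shown here, compound 4 is reported as "not active" with no number, so no step from compound 3 to compound 4 can be read. Nothing shown here offers an explanation for this result. The compounds shown leave open how far 4-hydroxypiperidin-1-yl in place of methylamino moves the number on this core.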